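The compounds below may be only part of what the source reports. "The series", "measured", "known", "first", "only" and "open" are said of these compounds alone.

Working notes on a small series built on one shared core, followed in a toxicity assay on CHO cells (Cricetulus griseus) for cytotoxicity, read by MTT assay, with a stated time of 72 h; a higher number here means a weaker inhibitor, a lower number a stronger inhibitor. Compound 1 (`O=C1/C(=C/c2ccc([N+](=O)[O-])cc2)S/C(=N\c2ccccc2)N1Cc1ccco1`), the 4-nitrophenyl member, has no single number to stand on: its entry reads "not determined" (no result reported). Compound 2 (`CCOc1ccc(/C=C2\S/C(=N\c3ccccc3)N(Cc3ccco3)C2=O)cc1`) gives no number either and reads "not determined" (no result reported). Compound 3 (`O=C1/C(=C/c2ccccn2)S/C(=N\c2ccccc2)N1Cc1ccco1`) reads > 250000 nM, which is a limit of this assay and not a number.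

Compound 4 (`Cc1ccc(/C=C2\S/C(=N\c3ccccc3)N(Cc3ccco3)C2=O)cc1`) differs from compound 1 in one place: methyl in place of nitro on an aromatic carbon. Put simply, the 4-nitrophenyl of compound 1 becomes 4-methylphenyl in compound 4. Among the measured compounds shown here, no step between measured compounds exists to size this change, and compound 1 offers no number to start from. For the measured compounds named here, the only reading to lean on is compound 3 at > 250000 nM, so no step beyond the scatter from that level is expected, and a further limit is a likely outcome. For compound 4 the estimated value is 200000 nM, with an expected range from 60000 nM to 400000 nM.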

Compound 4, half-maximal inhibitory concentration: 185000 nM
Compound 4: the middle estimate sits 1.1-fold (0.03 log units) above what was measured; measured number inside the range.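

In this assay compound 4 gives the series its first single number, 185000 nM, so the position on the double-bonded chain carbon can carry an aryl group that yields a reading. With 4-methylphenyl in place of pyridin-2-yl, the result is an at least 1.3-fold lower number from compound 3 to compound 4 (0.13 log units; that floor lies within the scatter), which establishes no real difference at this position. That step rests on a limit and not on a number: the limit of > 250000 nM in this assay, at which 1 of the 4 values shown sits.

The change from 4-nitrophenyl to 4-methylphenyl cannot be read, since compound 1 holds no number, and compound 2 holds none either. Going by these compounds, whether an amine or a carboxylic acid on that aromatic carbon, or a longer chain in place of methyl, would move the number beyond the scatter stays open.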